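This account rests on a few compounds, and the source may have more. Where it says the series, first, only, none or still open, it means among the compounds named here.

Measured so far in a functional assay on MCF7 cells (Homo sapiens) for antiproliferative activity; on this read-out lower numbers stand for stronger inhibition and higher numbers for weaker inhibition:
Compound 1 `C#CCCCn1c(Cc2cc(OC)c(OC)c(OC)c2)nc2c(N)nc(F)nc21` gives 11000 nM
Compound 2 `CCC(CC)Cn1c(Cc2cc(OC)c(OC)c(OC)c2)nc2c(N)ncnc21` gives 158000 nM

Compound 1 stands at the lower of the two numbers; compound 2 gives a higher one, and that gap lies beyond the usual scatter. Compound 3 `CCCn1c(Cc2cc(OC)c(OC)c(OC)c2)nc2c(N)nc(F)nc21` has not yet been measured. It differs from compound 1 by hydrogen in place of ethynyl on a saturated chain carbon, three bonds along the chain from an aromatic nitrogen. Among the measured compounds shown here, no measured pair shows this change, so the step expected here, a 1.8-fold higher number from compound 1 to compound 3 (0.26 log units; within the scatter), is a modest rise in the number, about at the edge of the scatter. Compound 3 is estimated at 20000 nM, within 5000 nM to 80000 nM.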

Compound 3, half-maximal inhibitory concentration: 25100 nM
The estimate for compound 3 lay 1.3-fold (0.10 log units) below the measured number; measured number inside the range.
By their numbers in this assay, from the lowest: compound 1; then compound 3; then compound 2.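

In this assay the change reads a 2.3-fold higher number from compound 1 to compound 3 (0.36 log units; beyond the scatter) when hydrogen replaces ethynyl on a saturated chain carbon, three bonds along the chain from an aromatic nitrogen. Among the compounds shown here, this gives the first direct comparison at this position: the pent-4-yn-1-yl chain of compound 1 gives a lower number than the propyl chain of compound 3, though the ethynyl end is not needed for a measurable value. No available evidence accounts for this difference. From the compounds shown here alone, whether an amine or a carboxylic acid at this chain end would lower the number remains open, as does the effect of a longer saturated chain.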